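Ethyl in Place of Acid Hydrogen on a Bromophenyl Core

A few compounds are considered here, and "the series" means these few. Any claim that something is new, unique, unknown or untested is made for them only; others in the source may bear on it.

Compound 1 `C=C(C)[C@H]1CC=C(C)[C@@]2(O)[C@@H]1[C@H](c1ccc(Cl)cc1Cl)O[C@@H]2C(=O)OCC` and compound 2 `C=C(C)[C@H]1CC=C(C)[C@@]2(O)[C@@H]1[C@H](c1ccccc1Br)O[C@@H]2C(=O)O` share a core and differ in two places, one of them being the group on the oxygen next to a carbonyl group. In a functional assay on KB3 cells (Homo sapiens) for antiproliferative activity, read by MTT assay, with a stated time of 96 h (a higher number here means a weaker inhibitor, a lower number a stronger inhibitor), compound 1 gives 3000 nM. Compound 2 gives only > 100000 nM in this assay, which is a limit of the assay rather than a number. Compound 2 therefore stands at the limit of > 100000 nM in this assay, at which 1 of the 2 values shown sits.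

Compound 3 `C=C(C)[C@H]1CC=C(C)[C@@]2(O)[C@@H]1[C@H](c1ccccc1Br)O[C@@H]2C(=O)OCC`, not yet measured, comes from compound 2 by one change: ethyl in place of hydrogen on an oxygen next to a carbonyl group. Among the compounds with values here, no pair of measured compounds differs by this change alone, so its size is not known from a direct comparison. Still, compound 1 carries the same ethoxycarbonyl group and in this assay gives 3000 nM, so a move toward measurable inhibition, that is toward a lower number, is expected for compound 3. The expected size of that step is an at least 16-fold lower number from compound 2 to compound 3 (1.22 log units; beyond the scatter). In this assay compound 3 is estimated to give about 6000 nM, with a range from 1000 nM to 40000 nM.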

Compound 3, half-maximal inhibitory concentration: 20000 nM
Estimate against measurement, compound 3: 3.3-fold (0.52 log units) below, and the stated range covers the measured number.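

The ethyl in place of hydrogen on an oxygen next to a carbonyl group can now be read on its own in this assay: it gives an at least 5.0-fold lower number from compound 2 to compound 3 (0.69 log units; beyond the scatter), so on this core the ethoxycarbonyl compound has a measurable number where the carboxy compound does not. That size is only a minimum, because compound 2 sits at a limit of the assay and not at a number: the limit of > 100000 nM in this assay, at which 1 of the 3 values shown sits.

The ethoxycarbonyl group does not set the level alone, since 2-bromophenyl in place of 2,4-dichlorophenyl on a saturated ring carbon gives a 6.7-fold higher number from compound 1 to compound 3 (0.82 log units; beyond the scatter) with the ethoxycarbonyl group unchanged.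

The compounds shown leave open whether a methyl group or a longer chain such as butyl on that oxygen would move the number further, and whether the ethyl step has a similar size on the 2,4-dichlorophenyl compound. They also cannot separate the two parts of the aryl change, bromine against chlorine and the second chlorine, which would take a compound such as the 2-chlorophenyl ethyl ester.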